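Isobutyl to cyclopentyl on a fluorinated antiproliferative series

The compounds below may be only part of what the source reports. "The series", "measured", "known", "first", "only" and "open" are said of these compounds alone.

Measured in a functional assay on A549 cells (Homo sapiens) for antiproliferative activity, read by MTT assay, with a stated time of 72 h (a higher number here means a weaker inhibitor, a lower number a stronger inhibitor), as follows

compound 1 `N=C(NC(=N)NC1CCCC1)Nc1ccc(C(F)(F)F)cc1` gives 1800 nM
compound 2 `CC(C)CNC(=N)NC(=N)Nc1ccc(F)cc1F` gives 3600 nM
compound 3 `CC(C)NC(=N)NC(=N)Nc1ccc(F)c(F)c1` gives 5200 nM

Compound 2 holds the middle place of these three numbers, but it lies within the scatter of both compound 1 and compound 3, so the data give it no clear rank against either. Compound 4 `N=C(NC(=N)NC1CCCC1)Nc1ccc(F)cc1F` departs from compound 2 in a single place (cyclopentyl in place of isobutyl on an amine nitrogen), with cyclopentyl in place of isobutyl on an amine nitrogen. Among the measured compounds shown here, no measured pair isolates this change. For the measured compounds named here, the only guide is compound 1, which also carries cyclopentyl and gives 1800 nM in this assay on a different aromatic substituent. A slight drop in the number is therefore expected, but nothing beyond the scatter. The expected step of a 1.3-fold lower number from compound 2 to compound 4 (0.12 log units; within the scatter) is accordingly a small one. In this assay compound 4 is estimated at 2700 nM (expected range 1200 nM to 6000 nM).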

Compound 4, half-maximal inhibitory concentration: 4000 nM
Compound 4: middle estimate off by 1.5-fold (0.17 log units), on the low side, within the range that was stated.
By their numbers in this assay, from the lowest: compounds 1, 2, 4 and 3 (each within the scatter of the next, the first and the last beyond it).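

Among the compounds shown here, this is the first measured pair that isolates cyclopentyl in place of isobutyl on an amine nitrogen, and in this assay it reads a 1.1-fold higher number from compound 2 to compound 4 (0.05 log units; within the scatter). With the rest of the structure held the same, the open chain and the five-membered ring of carbon are therefore not told apart at this position, even though the ring brings one more carbon. No supporting data bear on why the exchange reads this way.

Still open, going by these compounds, is whether any group on this nitrogen would move the number beyond the scatter, such as a cyclohexyl ring, a longer chain like hexyl, or a chain ending in a carboxylic acid. On these data alone, it is also open whether the same exchange would read alike with the trifluoromethyl group that compound 1 carries on its aromatic ring.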